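This account rests on a few compounds, and the source may have more. Where it says the series, first, only, none or still open, it means among the compounds named here.

Measured so far:
Compound 1, `CC1=C(C(=O)OCc2ccccc2)C(c2ccco2)NC(=O)N1`, gives 3% in an assay on membranes from HeLa cells for displacement of a labelled ligand from adenosine receptor A3 (Homo sapiens), read by scintillation counting, with a stated time of 180 min, tested at 1 uM; a higher number here means more inhibition at the concentration tested (going by the name of the read-out), a lower number less inhibition.
Compound 2, `CCN(CC)C(=O)C1=C(C)NC(=O)NC1c1ccco1`, gives 19% in this assay.
Compound 3, `CC1=C(C(=O)SC(C)C)C(c2ccco2)NC(=O)N1`, gives 1% in this assay.

Compound 3 has the lowest of the three numbers, though its gap to compound 1 lies within the usual scatter; only compound 2 stands clearly apart. Within the data shown here, the one measured step, a number 18 percentage points lower from compound 2 to compound 3 (beyond the scatter), replaced a diethylamino with an isopropylsulfanyl on a carbonyl carbon. Compound 4, `CC1=C(C(=O)OC2CCC2)C(c2ccco2)NC(=O)N1`, makes a different change: cyclobutyloxy in place of isopropylsulfanyl on a carbonyl carbon. Among the measured compounds shown here, no measured step covers that swap directly. Like compound 4, compound 1 carries an oxygen rather than a sulfur on the carbonyl carbon, and compound 1 gives 3%, sitting alongside compound 3. Compound 4 is therefore expected to show a number 3 percentage points higher from compound 3 to compound 4 (within the scatter), nothing beyond the scatter. The estimate for compound 4 is 4%, between -4% and 14%.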

Compound 4, a percentage reported as inhibition, at one concentration (the size of the read-out at that concentration, not a potency): 1%
Estimate against measurement, compound 4: 3 percentage points above; the measured number falls inside the stated range.
By their numbers in this assay, from the lowest: compounds 3, 4 and 1 (each within the scatter of the next); then compound 2.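

Cyclobutyloxy in place of isopropylsulfanyl on the carbonyl carbon gives no change at the digits printed from compound 3 to compound 4 (within the scatter) in this assay and cyclobutyl in place of benzyl on the oxygen gives a number 2 percentage points lower from compound 1 to compound 4 (within the scatter) there. Cyclobutyloxy in place of diethylamino gives a number 18 percentage points lower from compound 2 to compound 4 (beyond the scatter) so compound 2 alone stands apart, while the three other groups on that carbon read alike. Nothing measured here bears on the reason for this result. As far as these compounds go, whether a carboxylic acid, a primary amide or a dipropylamino group at this carbon would move the number stays open.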